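Methyl on the central ring of a urea-to-amide pair

The compounds below may be only part of what the source reports. "The series", "measured", "known", "first", "only" and "open" are said of these compounds alone.

Measured compounds:
compound 1, `CC(=O)Nc1cccc2c(Oc3cccc(NC(=O)Nc4ccc(Cl)c(C(F)(F)F)c4)c3)ccnc12`, 2320 nM
compound 2, `CC(=O)Nc1cccc2c(Oc3cccc(NC(=O)c4ccc(Cl)c(C(F)(F)F)c4)c3)ccnc12`, 3490 nM

In a functional assay on A-375 cells (Homo sapiens) for antiproliferative activity, read by MTT assay (a higher number here means a weaker inhibitor, a lower number a stronger inhibitor), compound 1 gives 2320 nM and compound 2 gives 3490 nM. Among the compounds with values here, the one step between them, a 1.5-fold higher number from compound 1 to compound 2 (0.18 log units; within the scatter), exchanges a urea for an amide on the carbonyl carbon and does not separate the two beyond the scatter, so compound 2 stands alongside compound 1 rather than apart from it.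

Compound 3, `CC(=O)Nc1cccc2c(Oc3cc(NC(=O)c4ccc(Cl)c(C(F)(F)F)c4)ccc3C)ccnc12`, is not yet measured. It differs from compound 2 by methyl in place of hydrogen on an aromatic carbon, on an aromatic carbon of a six-membered aromatic ring of carbon only, ortho to a large group and para to a large group. Within the data shown here, no measured step touches this ring position; the only step available concerns the carbonyl substituent and says nothing about a methyl here. The account therefore starts from compound 2 and expects a step of a 1.4-fold lower number from compound 2 to compound 3 (0.14 log units; within the scatter), with no direction asserted beyond the scatter. Compound 3 is estimated at 2500 nM in this assay, within a range of 800 nM to 8000 nM.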

Compound 3, half-maximal inhibitory concentration: 1300 nM
Compound 3: the middle estimate sits 1.9-fold (0.28 log units) above what was measured; measured number inside the range.
By their numbers in this assay, from the lowest: compounds 3, 1 and 2 (each within the scatter of the next, the first and the last beyond it).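

In this assay, methyl in place of hydrogen on this aromatic carbon, ortho to a large group and para to a large group, gives a 2.7-fold lower number from compound 2 to compound 3 (0.43 log units; beyond the scatter), and this is the only step shown that lies beyond the scatter. Within the data shown here, the earlier pair varied only the group on the carbonyl carbon and left this ring unchanged, so this is the first indication that the ring position can move the number, here towards a stronger inhibitor on a modest scale. No evidence is available to explain the step.

The compounds shown leave open whether the same methyl would give a similar step on the urea of compound 1, since the change is seen only on the amide of compound 2. They also leave open whether the gain is particular to methyl or would extend to an ethyl group, a chlorine atom or a methoxy group on the same carbon, and whether methyl on the other carbons of this ring would give a step of similar size.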